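Debromination on two cores and its effect on half-life

The source may report more compounds than this note shows. Statements on the series, on what has been measured and on what is new or still open speak of the compounds shown alone.

This account concerns three measured compounds and one whose number is still to come. Compound 1 `CCCNC(=O)[C@@H]1C[C@H]2CCC[C@@H](C1)[C@@H]2NC(=O)c1cc2scnc2n1Cc1ccc(OC)cc1` and compound 2 `CCCNC(=O)[C@@H]1C[C@H]2CCC[C@@H](C1)[C@@H]2NC(=O)c1cc2sc(Br)nc2n1Cc1ccc(OC)cc1` share one core, the two differing only in that compound 1 carries hydrogen in place of bromo on an aromatic carbon. In an ADME assay on microsomes from liver (Homo sapiens) for metabolic stability (a lower number here means that the compound disappears faster, a higher number that the compound lasts longer), compound 2 gives 0.867 h, and compound 1 gives 0.743 h; the step is a 1.2-fold lower number from compound 2 to compound 1 (0.07 log units; within the scatter). Compound 3 `CCCNC(=O)C1CCN(C(=O)c2cc3cc(Br)ccc3n2Cc2ccc(OC)cc2)CC1` has a different core; how its core differs from that of compound 2 is not broken down here. In this assay compound 3 gives 0.0657 h, the lowest of the three numbers and well apart from both compound 1 and compound 2.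

Compound 4 `CCCNC(=O)C1CCN(C(=O)c2cc3ccccc3n2Cc2ccc(OC)cc2)CC1` is compound 3 with hydrogen in place of bromo on an aromatic carbon. Going by the values given here, this is the same kind of change as the one from compound 2 to compound 1, but not the same: there the bromo left a five-membered aromatic ring with one nitrogen and one sulfur, next to the ring nitrogen and next to the ring sulfur, whereas here it leaves a six-membered aromatic ring of carbon only, meta and para to a fused ring. Among the compounds with values here, with only one measured pair to go on, the expectation rests on that pair alone. For compound 4 the expected step is a 1.0-fold lower number from compound 3 to compound 4 (0.00 log units; within the scatter), resting on the measured step of a 1.2-fold lower number from compound 2 to compound 1 (0.07 log units; within the scatter), which did not move the number out of the scatter. Compound 4 is therefore estimated at 0.065 h, with a likely range from 0.03 h to 0.14 h.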

Compound 4, half-life: 0.0443 h
Estimate against measurement, compound 4: 1.5-fold (0.17 log units) above; low and high end bracket the measured number.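

On the core of compound 3, hydrogen in place of bromo on an aromatic carbon gives a 1.5-fold lower number from compound 3 to compound 4 (0.17 log units; within the scatter) in this assay, and this step agrees with the one measured on the core of compound 1: the same change on two cores in this assay, a 1.2-fold lower number (0.07 log units; within the scatter) from compound 2 to compound 1 and a 1.5-fold lower number (0.17 log units; within the scatter) from compound 3 to compound 4, 1.3-fold (0.10 log units) apart, within the scatter of two such steps

Across these two pairs, therefore, the change carries from one core to the other without the half-life leaving the scatter, even though the bromo leaves a different kind of ring in each pair. This does not show that the change is without effect on every core or at every position, since two pairs on two cores are all that stand behind it, and as both steps lie within the scatter, their shared direction cannot be read as a real shortening of the half-life.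

The compounds shown leave open how a chloro, a fluoro or a nitrile on this aromatic carbon would compare with bromo and hydrogen on either core. They also leave open whether a hydroxyl or a fluoro in place of the methoxy group, which all four compounds carry, would change the half-life on either core.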